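Pyrazole chalcone series: trimethoxyphenyl gap on the ketone-side ring

This account rests on a few compounds, and the source may have more. Where it says the series, first, only, none or still open, it means among the compounds named here.

Measured compounds:
compound 1 `COc1cc(-c2cc(/C=C/C(=O)c3ccc(N)cc3)[nH]n2)cc(OC)c1OC` gives 1830 nM
compound 2 `COc1ccc(C(=O)/C=C/c2cc(-c3cc(OC)c(OC)c(OC)c3)n[nH]2)cc1OC` gives 1840 nM
compound 3 `COc1ccc(-c2cc(/C=C/C(=O)c3ccc(N)cc3)[nH]n2)cc1OC` gives 2280 nM

All three numbers come from a functional assay on M14 cells (Homo sapiens) for inhibition, read by sulforhodamine B assay, with a stated time of 48 h; on this read-out lower numbers stand for stronger inhibition of growth and higher numbers for weaker inhibition of growth. Compound 3 and compound 1 share a core and differ only by methoxy in place of hydrogen on an aromatic carbon; the step is a 1.2-fold lower number from compound 3 to compound 1 (0.10 log units; within the scatter). Compound 1 and compound 2 differ by the group on the carbonyl carbon, and the step is a 1.0-fold higher number from compound 1 to compound 2 (0.00 log units; within the scatter). Compound 2 and compound 3 differ in more than one place, and the difference between the two cores is not broken down here; their values sit within the scatter of each other.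

Compound 4 `COc1cc(C(=O)/C=C/c2cc(-c3cc(OC)c(OC)c(OC)c3)n[nH]2)cc(OC)c1OC` has not been measured. It differs from compound 2 by methoxy in place of hydrogen on an aromatic carbon, the same kind of change that takes compound 3 to compound 1, at a place described in the same words. Because that earlier step was a 1.2-fold lower number from compound 3 to compound 1 (0.10 log units; within the scatter), the step from compound 2 to compound 4 is expected to be similarly small, a 1.2-fold lower number from compound 2 to compound 4 (0.06 log units; within the scatter). On this basis compound 4 is estimated at 1600 nM in this assay, with a likely range from 800 nM to 3400 nM.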

Compound 4, concentration for 50% growth inhibition: 1790 nM
Compound 4: the middle estimate sits 1.1-fold (0.05 log units) below what was measured; the range from low to high includes it.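

In this assay, methoxy in place of hydrogen on an aromatic carbon gives a 1.0-fold lower number from compound 2 to compound 4 (0.01 log units; within the scatter), so this step shows no measurable effect of the added group on the core of compound 2. Set beside the earlier step, the change reads alike on both cores: the same change on two cores in this assay, a 1.2-fold lower number (0.10 log units; within the scatter) from compound 3 to compound 1 and a 1.0-fold lower number (0.01 log units; within the scatter) from compound 2 to compound 4, 1.2-fold (0.08 log units) apart, within the scatter of two such steps

This supports only a narrow statement: on these two cores, the added methoxy leaves the number within the scatter, and neither step is large enough to test whether the core alters the size of the effect, or to show that the change would stay this small on any other core.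

The compounds shown leave open whether a group other than methoxy at this place, such as a hydroxyl, a chlorine atom or a longer alkoxy chain, would move the number beyond the scatter. Also open, going by these compounds, is whether a carboxylic acid on the ring attached to the carbonyl would do so.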